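Swapping a Fused Benzothiazole for a Small Triazole

The compounds below may be only part of what the source reports. "The series", "measured", "known", "first", "only" and "open" are said of these compounds alone.

Compound 2 `Cn1c(-c2ccc(NC(=O)CSc3nc4ccccc4s3)cc2)nc(-c2ccccc2)c1-c1ccccc1` gives 50.3% in a functional assay on MCF7 cells (Homo sapiens) for cytotoxicity, read by MTT assay, with a stated time of 24 h, tested at 16 ug/mL (a higher number here means a stronger effect of the compound at the concentration tested, a lower number a weaker effect), the higher of the two numbers shown, though only within the scatter; compound 1 `Cc1ccc2oc(SCC(=O)Nc3ccc(-c4nc(-c5ccccc5)c(-c5ccccc5)n4C)cc3)nc2c1` gives 40.3%, and the step of a number 10 percentage points higher from compound 1 to compound 2 (within the scatter) is small. Compound 3 `Cn1cnnc1SCC(=O)Nc1ccc(-c2nc(-c3ccccc3)c(-c3ccccc3)n2C)cc1` differs from compound 2 in one place: 4-methyl-4H-1,2,4-triazol-3-yl in place of 1,3-benzothiazol-2-yl on a sulfur. Among the compounds with values here, the one measured step exchanged one fused bicyclic group for another on the same sulfur, whereas the change to compound 3 drops the six-membered ring of carbon only, so that step offers only weak guidance. A step of a number 12.3 percentage points lower from compound 2 to compound 3 (beyond the scatter) is expected, modest at most. Compound 3 is estimated at 38%, between 20% and 55%.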

Compound 3, a percentage reported as activity, at one concentration (the size of the read-out at that concentration, not a potency): 61.2%
Compound 3: middle estimate off by 23.2 percentage points, on the low side, and the stated range ends below it.
By their numbers in this assay, from the lowest: compounds 1 and 2 (each within the scatter of the next); then compound 3.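

Removing the six-membered ring of carbon only does no harm at this sulfur: with the 4-methyl-4H-1,2,4-triazol-3-yl group, this assay shows a number 10.9 percentage points higher from compound 2 to compound 3 (beyond the scatter) and also a number 20.9 percentage points higher from compound 1 to compound 3 (beyond the scatter) despite the group's fewer heavy atoms. Compound 1 and compound 2 both carry fused bicyclic groups, so only now is it clear that such a group is not needed here. No measurement available explains this gain. As far as these compounds go, whether a 1-methyl-1H-tetrazol-5-yl or a 1-methyl-1H-imidazol-2-yl group on the same sulfur would match the triazole remains open.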